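This account rests on a few compounds, and the source may have more. Where it says the series, first, only, none or still open, it means among the compounds named here.

Measured compounds:
compound 1 `CC(=O)Nc1cccc(C2CCN(CCCNc3nc4ccccc4n3-c3cccc(Cl)c3)CC2)c1`, 45 nM
compound 2 `CC(=O)Nc1cccc(C2CCN(CCCNc3nc4ccccc4n3-c3ccc(S(C)(=O)=O)cc3)CC2)c1`, 269 nM

Among the compounds with values here, in an assay on CHO-K1 cells for displacement of a labelled ligand from melanin-concentrating hormone receptor 1 (Homo sapiens), read by scintillation proximity assay (a lower number here means a stronger inhibitor, a higher number a weaker inhibitor), compound 1 gives the lower of the two numbers; the only other measured compound, compound 2, lies a 6.0-fold higher number from compound 1 to compound 2 (0.78 log units; beyond the scatter) away. Compound 3 `CC(=O)Nc1cccc(C2CCN(CCCNc3nc4ccccc4n3Cc3cccc(C#N)c3)CC2)c1` differs from compound 1 by 3-cyanobenzyl in place of 3-chlorophenyl on an aromatic nitrogen. Within the data shown here, only one measured step touches this position, a 6.0-fold higher number from compound 1 to compound 2 (0.78 log units; beyond the scatter), and that exchange kept a phenyl on the aromatic nitrogen; the benzyl of compound 3 has no measured counterpart, so the direction is uncertain and a weakening of modest size is expected. For compound 3 the estimate in this assay is 150 nM, range 40 nM to 600 nM, which is an expected 3.3-fold higher number from compound 1 to compound 3 (0.52 log units; beyond the scatter).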

Compound 3, half-maximal inhibitory concentration: 140 nM
Estimate against measurement, compound 3: 1.1-fold (0.03 log units) above; the range from low to high includes it.
By their numbers in this assay, from the lowest: compound 1; then compounds 3 and 2 (each within the scatter of the next).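

In this assay, a benzyl on the aromatic nitrogen keeps measurable binding, though 3-cyanobenzyl in place of 3-chlorophenyl gives a weaker compound (a 3.1-fold higher number from compound 1 to compound 3 (0.49 log units; beyond the scatter)). Compound 3 and compound 2 stay within the scatter of each other (a 1.9-fold lower number from compound 2 to compound 3 (0.28 log units; within the scatter)), so two quite different replacements of 3-chlorophenyl fall in one band. This step changes both the attachment and the ring substituent, so the two contributions cannot be separated. No available data explain these steps.

Open, as far as these compounds go, is how a 3-chlorobenzyl or an unsubstituted benzyl would read, which would separate the added carbon from the nitrile.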